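From a pyrrole to a thiophene on the hydrazone carbon

The compounds below may be only part of what the source reports. "The series", "measured", "known", "first", "only" and "open" are said of these compounds alone.

Three thiosemicarbazones sharing one core have been measured in a functional assay on PC-3 cells (Homo sapiens) for inhibition, read by sulforhodamine B assay, with a stated time of 48 h; a higher number here means a weaker inhibitor of growth, a lower number a stronger inhibitor of growth. Compound 3 (`CC1=CC[C@H](C(C)(C)NC(=S)N/N=C/c2ccc[nH]2)CC1`) stands at the weak end of the set: in this assay compound 3 gives only a limit, > 100000 nM, and not a number (the limit of > 100000 nM in this assay, at which 1 of the 3 values shown sits). Compound 1 (`CC1=CC[C@H](C(C)(C)NC(=S)N/N=C/c2ccc(O)cc2)CC1`) gives 53800 nM in this assay. Compound 2 (`CC1=CC[C@H](C(C)(C)NC(=S)N/N=C/c2ccc(F)cc2)CC1`) also gives only a limit in this assay, < 900 nM (the limit of < 900 nM in this assay, at which 1 of the 3 values shown sits). Moving from the hydroxyphenyl ring to the pyrrolyl ring gave an at least 1.8-fold higher number from compound 1 to compound 3 (0.26 log units; that floor lies within the scatter), while moving from the fluorophenyl ring gave an at least 110-fold higher number from compound 2 to compound 3 (2.04 log units; beyond the scatter).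

Compound 4 (`CC1=CC[C@H](C(C)(C)NC(=S)N/N=C/c2cccs2)CC1`) differs from compound 3 in one place: thiophen-2-yl in place of 1H-pyrrol-2-yl on a carbon with a double bond to nitrogen. For the measured compounds named here, no measured step swaps one five-membered ring for another, so the two steps just named only show where the neighbours of compound 3 lie. The change itself is small in atoms; a hydrogen-bond donor leaves and a hydrogen-bond acceptor enters. With compound 3 already at the upper limit, any change that is seen can only be a lower number, and a modest one is expected, a step of about an at least 2.5-fold lower number from compound 3 to compound 4 (0.39 log units; beyond the scatter). Compound 4 is therefore estimated to give about 40000 nM in this assay, within 8000 nM to 100000 nM.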

Compound 4, concentration for total growth inhibition: 62800 nM
Compound 4: middle estimate off by 1.6-fold (0.20 log units), on the low side; measured number inside the range.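

In this assay, replacing 1H-pyrrol-2-yl with thiophen-2-yl at this carbon trades a hydrogen-bond donor for a hydrogen-bond acceptor and gives an at least 1.5-fold lower number from compound 3 to compound 4 (0.20 log units; that floor lies within the scatter), and this step is only a floor because compound 3 sits at a limit: the limit of > 100000 nM in this assay, at which 1 of the 4 values shown sits. Compound 4 nevertheless gives this position its first exact number for a five-membered ring, and that number cannot be told apart from the one for the 4-hydroxyphenyl ring, with a 1.2-fold higher number from compound 1 to compound 4 (0.07 log units; within the scatter). The 4-fluorophenyl ring remains far from the thiophen-2-yl ring, with an at least 69-fold higher number from compound 2 to compound 4 (1.84 log units; beyond the scatter), and this step is also a floor because compound 2 sits at a limit: the limit of < 900 nM in this assay, at which 1 of the 4 values shown sits.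

On these data alone, the true size of the change from 1H-pyrrol-2-yl to thiophen-2-yl stays open, as does whether the swap of a ring nitrogen for a ring sulfur has any real effect on the number in this assay. A furan-2-yl ring would add a third five-membered ring to the comparison, and a 4-chlorophenyl ring would test whether the low number of compound 2 is particular to fluoro.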